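Swapping a chlorophenyl for a benzimidazole in sulfonamide series

The source may hold more compounds than are shown below. What is called first, only, known or untested is meant among the compounds shown, and "the series" means these compounds.

Measured compounds:
Compound 1, `COc1ccc(CN(c2cc(OC)c(OC)c(OC)c2)S(=O)(=O)c2ccc(C(C)(C)C)cc2)cc1`: 28600 nM
Compound 2, `COc1ccc(CN(c2cc(OC)c(OC)c(OC)c2)S(=O)(=O)c2ccc(OC)c(OC)c2)cc1`: 20100 nM
Compound 3, `COc1cc(N(Cc2ccc(Cl)cc2)S(=O)(=O)c2ccc(C)cc2)cc(OC)c1OC`: 14600 nM

All three were tested in a functional assay on PC-3 cells (Homo sapiens) for inhibition, read by MTT assay, with a stated time of 48 h; on this read-out higher numbers stand for weaker inhibition and lower numbers for stronger inhibition. Compound 3 gives the lowest of the three numbers, yet each of the three values lies within the usual scatter of the others, so no order among them can be claimed. For the measured compounds named here, the only single-point step in the set, a 1.4-fold lower number from compound 1 to compound 2 (0.15 log units; within the scatter), concerns the group on the sulfonyl sulfur, not the part that changes next.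

Compound 4, `COc1cc(N(Cc2nc3ccccc3[nH]2)S(=O)(=O)c2ccc(C)cc2)cc(OC)c1OC`, differs from compound 3 by 1H-benzimidazol-2-yl in place of 4-chlorophenyl on a saturated chain carbon bound to a sulfonamide nitrogen. Going by the values given here, no measured step touches this benzylic position, so there is nothing to scale the expectation from, and the change is a large one: a halogenated carbon ring gives way to a fused ring bearing a hydrogen-bond donor and an acceptor. In the absence of any guiding step, compound 4 is expected to land near compound 3, with a 1.0-fold lower number from compound 3 to compound 4 (0.02 log units; within the scatter) reflecting no predicted move beyond the scatter, though with a wide margin. The estimate for compound 4 is 14000 nM, ranging from 4000 nM to 50000 nM.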

Compound 4, half-maximal inhibitory concentration: 3340 nM
Beside the measured number, compound 4's estimate is 4.2-fold (0.62 log units) above it; the measured number lies below the stated range.
By their numbers in this assay, from the lowest: compound 4; then compounds 3, 2 and 1 (each within the scatter of the next).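

In this assay the change to 1H-benzimidazol-2-yl from 4-chlorophenyl on a saturated chain carbon bound to a sulfonamide nitrogen gives a 4.4-fold lower number from compound 3 to compound 4 (0.64 log units; beyond the scatter) and is the only step shown that lies beyond the scatter. For the compounds shown here, this position, which no earlier pair had tested, can therefore shift the number toward stronger inhibition, although the step is only modest in size. Nothing measured here explains the shift or shows whether the added nitrogens, the larger group or the loss of chlorine is responsible.

A plain phenyl, a 2-pyridyl or a 1-methylbenzimidazol-2-yl at the same place could help separate those parts of the change. On these data alone, it also remains open whether the same swap gives a similar step when the sulfonyl sulfur carries the groups seen in compound 1 and compound 2.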